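Cytotoxicity notes on a biaryl amide series

The compounds below may be only part of what the source reports. "The series", "measured", "known", "first", "only" and "open" are said of these compounds alone.

Measured so far:
- compound 1 `CCOC(=O)CCCCCOc1cccc(CN(C(=O)c2ccc(-c3cccc(Oc4ccccc4)c3)cc2)C(C)C)c1`: in an ADME assay on BJ cells (Homo sapiens) for cytotoxicity, read by CellTiter-Glo and resazurin assay, with a stated time of 72 h (on this read-out higher numbers stand for an effect only at larger amounts of compound and lower numbers for an effect already at smaller amounts), compound 1 reports only a limit, > 19600 nM.
- compound 2 `CCOC(=O)CCCCCOc1cccc(CN(C(=O)c2ccc(-c3ccc(Cl)c(Cl)c3)cc2)C(C)C)c1`: in this assay compound 2 also reports only a limit, > 26000 nM.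

Compound 2 sits at the limit of > 26000 nM in this assay, at which 1 of the 2 values shown sits. Compound 1 sits at the limit of > 19600 nM in this assay, at which 1 of the 2 values shown sits. Going by the values given here, neither value is a number, so no measured step between the two exists.

Compound 3 `CCOC(=O)CCCCCOc1cccc(CN(C(=O)c2ccc(-c3cccc(S(C)(=O)=O)c3)cc2)C(C)C)c1` carries 3-(methylsulfonyl)phenyl in place of 3,4-dichlorophenyl on an aromatic carbon. Among the compounds with values here, for this change no measured step is available. In this assay the expected step of a number no higher from compound 2 to compound 3 (the limit leaves the size open) stays within the scatter, most likely again as a limit. Compound 3 is estimated at 26000 nM, range 10000 nM to 60000 nM.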

Compound 3, half-maximal effective concentration: > 26000 nM
Compound 3 was reported as a limit; the forecaster's own chance of this, stated with the estimate: 80%; the middle value lies on the limit itself.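

Compound 1, compound 2 and compound 3 all report only limits, so no step to compound 3 can be read: the limit of > 26000 nM in this assay, at which 2 of the 3 values shown sit.

Still open is whether any of these compounds has a measurable half-maximal effective concentration, and how 3-(methylsulfonyl)phenyl and 3,4-dichlorophenyl compare.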